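The compounds below may be only part of what the source reports. "The series", "measured", "known", "first", "only" and "open" are said of these compounds alone.

In a functional assay on DU-145 cells (Homo sapiens) for antiproliferative activity, read by propidium iodide staining, with a stated time of 96 h (on this read-out higher numbers stand for weaker inhibition and lower numbers for stronger inhibition), compound 1 (`CC(O)(CSc1ccc(F)cc1)C(=O)Nc1cccc(S(F)(F)(F)(F)F)c1`) gives 38500 nM and compound 2 (`CC(O)(CSc1ccc(C(F)(F)F)cc1)C(=O)Nc1cccc(S(F)(F)(F)(F)F)c1`) gives 27200 nM while compound 3 (`CC(O)(CSc1cccc(C(F)(F)F)c1)C(=O)Nc1cccc(S(F)(F)(F)(F)F)c1`) gives 19100 nM and so stands within the scatter of both. Compound 4 (`CC(O)(CSc1ccccc1C(F)(F)F)C(=O)Nc1cccc(S(F)(F)(F)(F)F)c1`) differs from compound 3 by one change (2-(trifluoromethyl)phenyl in place of 3-(trifluoromethyl)phenyl on a sulfur) with 2-(trifluoromethyl)phenyl in place of 3-(trifluoromethyl)phenyl on a sulfur. The closest measured precedent (a 1.4-fold lower number from compound 2 to compound 3 (0.15 log units; within the scatter)) lies within the scatter. The two other steps (a 1.4-fold lower number from compound 1 to compound 2 (0.15 log units; within the scatter)) and (a 2.0-fold lower number from compound 1 to compound 3 (0.30 log units; within the scatter)) also lie within it. Among the compounds with values here, no compound carrying 2-(trifluoromethyl)phenyl has been measured, so no step beyond the scatter is expected in this assay for this change. The expected step (a 1.3-fold higher number from compound 3 to compound 4 (0.10 log units; within the scatter)) stays within the scatter. The estimated value for compound 4 is 24000 nM (expected range 10000 nM to 50000 nM).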

Compound 4, half-maximal inhibitory concentration: 15800 nM
For compound 4 the middle estimate is 1.5-fold (0.18 log units) above the measured one, and the stated range covers the measured number.
By their numbers in this assay, from the lowest: compounds 4, 3, 2 and 1 (each within the scatter of the next, the first and the last beyond it).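

In this assay, the 2-(trifluoromethyl)phenyl group on the sulfur leaves the number within the scatter of the other two trifluoromethyl isomers, with a 1.2-fold lower number from compound 3 to compound 4 (0.08 log units; within the scatter) and a 1.7-fold lower number from compound 2 to compound 4 (0.24 log units; within the scatter), so these isomers are not separated. Within the data shown here, only a 2.4-fold lower number from compound 1 to compound 4 (0.39 log units; beyond the scatter) passes beyond the scatter, the sole such step, and it is modest. Nothing at hand explains these steps. Open, from the compounds shown here alone, is whether an amine or a carboxylic acid on the phenyl ring, or a longer chain on the sulfur in place of the ring, would give a larger step.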